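Swapping Methyl for Phenyl on Compound 2

The compounds below may be only part of what the source reports. "The series", "measured", "known", "first", "only" and "open" are said of these compounds alone.

In a functional assay on BMEC cells (Bos taurus) for antiproliferative activity (a higher number here means a weaker inhibitor, a lower number a stronger inhibitor), compound 2 `COc1cc(/C=C\Cc2cc(O)c3cc(C)oc3c2)cc(OC)c1OC` gives 93 nM. Where compound 2 has methyl, compound 1 `COc1cc(/C=C\Cc2cc(O)c3ccoc3c2)cc(OC)c1OC` has hydrogen, and compound 1 gives 49 nM. That is a 1.9-fold higher number from compound 1 to compound 2 (0.28 log units; within the scatter), so the two cannot be told apart. Compound 3 `COc1cc(/C=C/Cc2cc(O)c3cc(C)oc3c2)cc(OC)c1OC` gives 12300 nM, which is a 130-fold higher number from compound 2 to compound 3 (2.12 log units; beyond the scatter). This large gap is due to the fact that compounds 2 and 3 differ only in the configuration as drawn, so compound 2 sits far from compound 3.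

Compound 4 `COc1cc(/C=C\Cc2cc(O)c3cc(-c4ccccc4)oc3c2)cc(OC)c1OC` keeps the double bond of compound 2 but carries phenyl in place of methyl on an aromatic carbon. The step from compound 1 bears most directly, since it changes the same carbon, and it stayed small at a 1.9-fold higher number from compound 1 to compound 2 (0.28 log units; within the scatter). Phenyl is a much bigger change than methyl, however, and no measured compound tests a group of that size there. The large geometry step concerns another part of the molecule and offers no guide. A moderate move towards a higher number seems likeliest, and the estimated step is a 2.7-fold higher number from compound 2 to compound 4 (0.43 log units; beyond the scatter). Compound 4 is expected at about 250 nM, within an estimated range of 40 nM to 2000 nM.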

Compound 4, half-maximal inhibitory concentration: > 2000 nM
Compound 4: no number, only a limit; the forecaster's own chance of this, stated with the estimate: 5%; at least 8.0-fold (0.90 log units) between middle value and limit.
By their numbers in this assay, from the lowest: compounds 1 and 2 (each within the scatter of the next); then compound 3.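

In this assay compound 4 reads > 2000 nM, which is a limit of the assay and not a number. Hydrogen and methyl could not be told apart at this carbon next to the ring oxygen, but phenyl there gives an at least 21-fold higher number from compound 2 to compound 4 (1.33 log units; beyond the scatter) and an at least 40-fold higher number from compound 1 to compound 4 (1.61 log units; beyond the scatter). The position is therefore not indifferent to what it carries, and the double bond is not the only place in this series where one change produces a large step.

The compounds shown leave open where along the way from methyl to phenyl the large step sets in, and ethyl, a longer chain such as butyl, or a small ring such as cyclopropyl would help to locate it. They also leave open whether a phenyl ring carrying a methoxy group, or a pyridine ring, would behave as phenyl does here.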